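The compounds below may be only part of what the source reports. "The series", "measured", "known", "first", "only" and "open" are said of these compounds alone.

Working notes on the series: in a functional assay on A549 cells (Homo sapiens) for cytotoxicity (a lower number here means that less compound is needed, a higher number that more compound is needed for the effect), compound 1 `COC1=C(C)C(=O)/C(=C(O)/C=C/c2ccc(Br)cc2)C(=O)C1(C)C` gives 1.4 ug/mL. Within the data shown here, compound 2 `COC1=C(C)C(=O)/C(=C(O)/C=C/c2ccc(OC)cc2)C(=O)C1(C)C` gives 3 ug/mL, the higher of the two numbers so far, and compound 1 is its only neighbour. Compound 3 `COC1=C(C)C(=O)/C(=C(O)/C=C/c2cccc(OC)c2)C(=O)C1(C)C` is still unmeasured. Its difference from compound 2 is 3-methoxyphenyl in place of 4-methoxyphenyl on a double-bonded chain carbon bound to a double-bonded chain carbon: the same atoms, joined differently, with 3-methoxyphenyl in place of 4-methoxyphenyl on a double-bonded chain carbon bound to a double-bonded chain carbon.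

Among the measured compounds shown here, the only measured step that bears on this is a 2.1-fold higher number from compound 1 to compound 2 (0.33 log units; beyond the scatter), which is modest and just beyond the scatter. That step exchanges bromo for methoxy on an aromatic carbon, whereas here the methoxy group is kept and only its place changes. For the measured compounds named here, the series holds no measured pair of this kind, so the data give no direction. A shift no larger than that modest step is therefore expected in this assay, most likely none beyond the scatter. The expected step is no change at the digits printed from compound 2 to compound 3 (within the scatter). For compound 3 the estimated value is 3 ug/mL, with an expected range of 1.4 ug/mL to 6.5 ug/mL.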

Compound 3, concentration for half-maximal effect: 2.8 ug/mL
Estimate against measurement, compound 3: 1.1-fold (0.03 log units) above; the range from low to high includes it.
By their numbers in this assay, from the lowest: compounds 1, 3 and 2 (each within the scatter of the next, the first and the last beyond it).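

In this assay, the move from 4-methoxyphenyl to 3-methoxyphenyl on a double-bonded chain carbon bound to a double-bonded chain carbon gives a 1.1-fold lower number from compound 2 to compound 3 (0.03 log units; within the scatter), so this single pair shows that the place of the methoxy group on the aromatic ring makes no difference beyond the scatter. The exchange of bromo for methoxy now reads differently according to the place of the methoxy group: a 2.1-fold higher number from compound 1 to compound 2 (0.33 log units; beyond the scatter) lies just beyond the scatter, whereas a 2.0-fold higher number from compound 1 to compound 3 (0.30 log units; within the scatter) stays within it, so the earlier gap does not carry over to the 3-methoxyphenyl compound. No supporting data bear on these steps, and they remain observations without an explanation.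

The compounds shown leave open whether bromo tolerates the same move on the aromatic ring as methoxy does, and whether the flat response to position holds in any setting other than these A549 cells. They also leave open what an amine or a carboxylic acid on the aromatic ring would do to the number in this assay.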